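Indolyl in place of benzimidazolyl: compound 4 from compound 1

A few compounds are considered here, and "the series" means these few. Any claim that something is new, unique, unknown or untested is made for them only; others in the source may bear on it.

Within the data shown here, compound 1 `COc1ccccc1N1CCN(CCCCCn2nc(-n3cnc4ccccc43)ccc2=O)CC1` gives 3.1 nM in an assay on cell membranes from brain for binding affinity to Adrenergic receptor alpha-1 (Rattus norvegicus), read by radioligand binding (on this read-out higher numbers stand for weaker inhibition and lower numbers for stronger inhibition), the lowest of the three numbers measured so far. Compound 2 `O=c1ccc(-n2cnc3ccccc32)nn1CCCCCN1CCN(c2ccccc2Cl)CC1` gives 4.5 nM in this assay, and compound 3 `O=c1ccc(-n2ccnc2)nn1CCCCCCN1CCN(c2ccccc2Cl)CC1` gives 29.7 nM. Among the measured compounds shown here, the one single-point step measured, a 1.5-fold higher number from compound 1 to compound 2 (0.16 log units; within the scatter), concerns the substituent on the outer aromatic ring and not the group on the shared core, so no measured step speaks directly to the change that leads to compound 4 `COc1ccccc1N1CCN(CCCCCn2nc(-n3ccc4ccccc43)ccc2=O)CC1`: 1H-indol-1-yl in place of 1H-benzimidazol-1-yl on an aromatic carbon. Compound 3 carries a smaller five-membered aromatic group there, alongside other changes, and its number lies well above that of compound 1. For compound 4 a modest step is expected, a 1.6-fold higher number from compound 1 to compound 4 (0.21 log units; within the scatter). The number for compound 4 in this assay is estimated at 5 nM, between 1.5 nM and 16 nM.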

Compound 4, inhibition constant: 6.8 nM
Estimate against measurement, compound 4: 1.4-fold (0.13 log units) below, within the range that was stated.
By their numbers in this assay, from the lowest: compounds 1, 2 and 4 (each within the scatter of the next, the first and the last beyond it); then compound 3.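

In this assay, among these compounds, the first measured change at this position, on the aromatic carbon next to the ring nitrogen, is a 2.2-fold higher number from compound 1 to compound 4 (0.34 log units; beyond the scatter) for 1H-indol-1-yl in place of 1H-benzimidazol-1-yl. The two groups have the same heavy-atom count and ring sizes, differing in a ring nitrogen exchanged for carbon and one hydrogen-bond acceptor fewer, and the exchange leaves a modest step. No evidence on hand explains this step.

Open, going by these compounds, is how a morpholine or a plain phenyl group would read at this position. Also open, on these data alone, is whether the same exchange gives a step of like size with chloro in place of methoxy on the outer aromatic ring.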